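Changing the Ring on a Sulfonyl Sulfur

A few compounds are considered here, and "the series" means these few. Any claim that something is new, unique, unknown or untested is made for them only; others in the source may bear on it.

- Compound 1 `Cc1cc(=O)oc2cc(OCC(=O)NN(C(=O)c3ccncc3)C(=O)c3ccncc3)ccc12`: 8680 nM
- Compound 2 `O=c1oc2ccc(S(=O)(=O)N3CCOCC3)cc2cc1Br`: 13200 nM
- Compound 3 `O=c1oc2ccc(S(=O)(=O)N3CCCCC3)cc2cc1Br`: 2070 nM

These values come from a functional assay on MCF7 cells (Homo sapiens) for inhibition, read by MTT assay, with a stated time of 3 days; a lower number here means a stronger inhibitor, a higher number a weaker inhibitor. Among the three, compound 3 has the lowest number, at 2070 nM. Compound 4 `CN1CCN(S(=O)(=O)c2ccc3oc(=O)c(Br)cc3c2)CC1` keeps the shared core of compound 3 and has 4-methylpiperazin-1-yl in place of piperidin-1-yl on the sulfonyl sulfur (4-methylpiperazin-1-yl in place of piperidin-1-yl on a sulfonyl sulfur).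

For the measured compounds named here, only one measured step changes the group at this place: a 6.4-fold lower number from compound 2 to compound 3 (0.80 log units; beyond the scatter), with piperidin-1-yl in place of morpholin-4-yl. Compound 1 offers no such comparison. Read in reverse, that step shows a higher number when piperidin-1-yl is given up, and compound 4 gives up piperidin-1-yl as well. Still, 4-methylpiperazin-1-yl is not morpholin-4-yl, and one step is thin evidence. A smaller change in the same direction therefore seems the fair expectation in this assay. The estimated step is a 2.4-fold higher number from compound 3 to compound 4 (0.38 log units; beyond the scatter). For compound 4 the expected value is 5000 nM, with an estimated range from 1900 nM to 13000 nM.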

Compound 4, half-maximal inhibitory concentration: 31400 nM
Beside the measured number, compound 4's estimate is 6.3-fold (0.80 log units) below it, outside the stated range (above it).
By their numbers in this assay, from the lowest: compound 3; then compounds 1 and 2 (each within the scatter of the next); then compound 4.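

Swapping piperidin-1-yl for 4-methylpiperazin-1-yl in this assay gives a 15-fold higher number from compound 3 to compound 4 (1.18 log units; beyond the scatter), a large step even though both groups are one six-membered non-aromatic ring, so the number at this place depends strongly on what that ring carries. The change from morpholin-4-yl to 4-methylpiperazin-1-yl gives a 2.4-fold higher number from compound 2 to compound 4 (0.38 log units; beyond the scatter), which shows that giving up piperidin-1-yl does not lead to one shared higher level among these compounds. Nothing available explains why the number moves in this way.

The compounds shown leave open whether the rise follows the methyl or the second ring nitrogen, a question that plain piperazin-1-yl would help to separate. Going by these compounds, it is also open how a five-membered pyrrolidin-1-yl or an open-chain diethylamino group on the sulfonyl sulfur would compare with compound 3.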